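Chain Extension at the Benzylic Position in a Glucagon Receptor Series

The compounds below may be only part of what the source reports. "The series", "measured", "known", "first", "only" and "open" are said of these compounds alone.

Measured so far:
compound 1 `CCC[C@H](c1ccc(C(=O)NCc2nn[nH]n2)cc1)N1C(=O)C(c2cc(Cl)cc(Cl)c2)=N[C@]12CC[C@@H](C(C)(C)C)CC2` — 500 nM
compound 2 `C[C@H](c1ccc(C(=O)NCCC(=O)O)cc1)N1C(=O)C(c2cccc(Cl)c2F)=N[C@]12CC[C@@H](C(C)(C)C)CC2` — 4000 nM
compound 3 `CC(C)(C)CC[C@H](c1ccc(C(=O)NCc2nn[nH]n2)cc1)N1C(=O)C(c2ccc(F)cc2)=N[C@]12CC[C@@H](C(C)(C)C)CC2` — 90 nM

In an assay on membranes from liver for displacement of a labelled ligand from Glucagon receptor (Mus musculus), read by scintillation counting, with a stated time of 60 min (on this read-out higher numbers stand for weaker inhibition and lower numbers for stronger inhibition), compound 1 gives 500 nM, the second highest of the three numbers. Compound 3 sits nearest with 90 nM, a gap beyond the scatter, and compound 2 is furthest with 4000 nM, also beyond the scatter. Across these three compounds, the longer and more branched chain on the saturated chain carbon goes together with the lower number, though compound 2 and compound 3 also differ from compound 1 in the aromatic substituent on the shared core, so the chain is not the only variable.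

Compound 4 `CC(C)CC[C@H](c1ccc(C(=O)NCc2nn[nH]n2)cc1)N1C(=O)C(c2cc(Cl)cc(Cl)c2)=N[C@]12CC[C@@H](C(C)(C)C)CC2` differs from compound 1 in one place: isopropyl in place of methyl on a saturated chain carbon, three bonds along the chain from an amide-type nitrogen in a ring and an aromatic carbon. For the measured compounds named here, no measured pair shows this exact change. Given that compound 3, with the bulkier chain, gives 90 nM while compound 1 gives 500 nM, a modest downward step is expected; the step from compound 1 to compound 4 is estimated as a 2.5-fold lower number from compound 1 to compound 4 (0.40 log units; beyond the scatter), toward stronger inhibition but smaller than the gap to compound 3. Compound 4 is expected to give 200 nM, with a range of 70 nM to 600 nM.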

Compound 4, half-maximal inhibitory concentration: 280 nM
Beside the measured number, compound 4's estimate is 1.4-fold (0.15 log units) below it; low and high end bracket the measured number.
By their numbers in this assay, from the lowest: compound 3; then compounds 4 and 1 (each within the scatter of the next); then compound 2.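

Working notes on the benzylic chain: a 1.8-fold lower number from compound 1 to compound 4 (0.25 log units; within the scatter) in this assay is the first reading of this position with the aromatic substituent on the shared core held fixed, and it lies within the scatter. On the core of compound 1, the position therefore takes isopropyl in place of methyl, read further out as propyl to isopentyl, with no change that can be told apart from repeat measurement. This single pair gives no support for a chain-length trend on this core, and nothing available bears on why the step is this small.

What the chain of compound 3 and its aromatic substituent each contribute remains open, with no pair among the compounds shown separating the two. Also open, as far as these compounds go, is how this position responds to groups of another kind on the same core, such as a cyclopropyl ring, a hydroxyl group, an amine or a carboxylic acid on the chain, and whether the isopropyl result holds with the tetrazole amide replaced by the propanoic acid amide of compound 2.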